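Adding an Ester Arm to a Simple Phenyl Statin Mimic

The compounds below may be only part of what the source reports. "The series", "measured", "known", "first", "only" and "open" are said of these compounds alone.

Compound 1 `O=C(O)C[C@H](O)CC(=O)CCc1ccccc1`: 1.3 nM
Compound 2 `CC[C@H](C)C(=O)O[C@H]1C[C@@H](C)C[C@@H]2C=C[C@H](C)[C@H](CCC(O)C[C@@H](O)CC(=O)O)C12`: 1.6 nM
Compound 3 `CC[C@H](C)C(=O)O[C@H]1CCC=C2C=C[C@H](C)[C@H](CCC(=O)C[C@@H](O)CC(=O)O)C21`: 32 nM

Of the compounds shown here, three have been tested in an assay on microsomes from liver with 3-hydroxy-3-methylglutaryl-coenzyme A reductase (Rattus norvegicus) as the target; on this read-out lower numbers stand for stronger inhibition and higher numbers for weaker inhibition. Compound 1 gives 1.3 nM, the lowest of the three numbers; compound 2 sits within the scatter of it at 1.6 nM, while compound 3, at 32 nM, lies beyond the scatter. Compound 4 `CC[C@H](C)C(=O)OCc1ccccc1CCC(=O)C[C@@H](O)CC(=O)O` keeps the core of compound 1 and differs in one place: (((sec-butyl)carbonyl)oxy)methyl in place of hydrogen on an aromatic carbon, at a site described as on an aromatic carbon of a six-membered aromatic ring of carbon only, ortho to a large group. Going by the values given here, no measured pair shows what such an addition does in this assay, so the direction is open. Because compound 1 already stands at 1.3 nM, a step of a 1.2-fold higher number from compound 1 to compound 4 (0.06 log units; within the scatter) is expected, within the scatter. Compound 4 is estimated at 1.5 nM, with a range from 0.3 nM to 8 nM.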

Compound 4, half-maximal inhibitory concentration: 320000 nM
The estimate for compound 4 lay 210000-fold (5.33 log units) below the measured number; measured number above the stated range.
By their numbers in this assay, from the lowest: compounds 1 and 2 (each within the scatter of the next); then compound 3; then compound 4.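

In this assay, (((sec-butyl)carbonyl)oxy)methyl in place of hydrogen on this aromatic carbon, ortho to a large group, gives a 250000-fold higher number from compound 1 to compound 4 (5.39 log units; beyond the scatter). Going by these compounds alone, this single addition therefore removes nearly all of the inhibition seen with the core of compound 1, which the earlier compounds could not show. Nothing measured here accounts for a loss of this size. Still open, going by these compounds, is whether a methyl group, a hydroxymethyl group or an amine on this same carbon would fare any better. Also open, on these data alone, is whether the same ester arm would cost as much elsewhere on the ring.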